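Methyl to Fluoro on a Compound Beyond the Assay Limit

The source may report more compounds than this note shows. Statements on the series, on what has been measured and on what is new or still open speak of the compounds shown alone.

Compound 2 `COc1cc(-c2nnc(SCC(=O)Nc3ccccc3C)n2N)cc(OC)c1OC` carries a (2-methylphenyl)carbamoyl group. In a functional assay on PC-3 cells (Homo sapiens) for antiproliferative activity, read by MTT assay, with a stated time of 48 h (a higher number here means a weaker inhibitor, a lower number a stronger inhibitor), compound 2 gives only a limit, > 100000 nM. Compound 1 `COc1cc(-c2nnc(SCC(=O)c3ccccc3)n2N)cc(OC)c1OC` has a phenyl on the carbonyl carbon instead. In this assay compound 1 likewise gives only a limit, > 100000 nM. The step that the two limits leave unreadable from compound 1 to compound 2 can therefore not be read, as both values sit at the limit of > 100000 nM in this assay, at which 2 of the 2 values shown sit. Compound 3 `COc1cc(-c2nnc(SCC(=O)Nc3ccccc3F)n2N)cc(OC)c1OC` differs from compound 2 by fluoro in place of methyl on an aromatic carbon of a six-membered aromatic ring of carbon only, ortho to a large group, so that (2-methylphenyl)carbamoyl becomes (2-fluorophenyl)carbamoyl. Among the measured compounds shown here, no measured step bears on this change, and the two measured compounds set only limits, so no direction can be drawn from them. The step of a number no higher from compound 2 to compound 3 (the limit leaves the size open) is estimated to be nothing beyond the scatter. Compound 3 is accordingly expected to stay at the limit, with an estimate of 100000 nM, ranging from 30000 nM to 300000 nM.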

Compound 3, half-maximal inhibitory concentration: 36700 nM
Estimate against measurement, compound 3: 2.7-fold (0.44 log units) above, and the stated range covers the measured number.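

In this assay, among the compounds shown here, fluoro in place of methyl on an aromatic carbon, ortho to a large group, gives an at least 2.7-fold lower number from compound 2 to compound 3 (0.43 log units; beyond the scatter), so this position responds to a change of a single atom, something the earlier compounds could not show. Replacing the phenyl on the carbonyl carbon with (2-fluorophenyl)amino gives an at least 2.7-fold lower number from compound 1 to compound 3 (0.43 log units; beyond the scatter), so this change too yields a number within the range of the assay. The step between the two earlier compounds still cannot be read, and the full size of both new steps stays open, because the compounds they start from give only limits: the limit of > 100000 nM in this assay, at which 2 of the 3 values shown sit.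

The compounds shown leave open whether chloro, methoxy or an amine on the same carbon would lower the number further. They also leave open whether fluoro would have the same effect on another carbon of that ring.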